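A Cyclopropyl Amide on a Second Core

A few compounds are considered here, and "the series" means these few. Any claim that something is new, unique, unknown or untested is made for them only; others in the source may bear on it.

Compound 1, `Cc1cccc2c1/C(=C/C(=O)NC1CC1)CC2`, gives 17% in a functional assay on the whole organism with Mus musculus as the target, at a dose of 100 mg/kg by the intraperitoneal route; on this read-out lower numbers stand for less inhibition and higher numbers for more inhibition at the one dose given (going by the name of the read-out).
Compound 2, `NC(=O)/C=C1\CCc2cc(F)c(F)cc21`, gives 100% in this assay.
Compound 3, `Cc1cccc2c1/C(=C/C(N)=O)CC2`, gives 100% in this assay.

Compound 3 and compound 1 share a core and differ by cyclopropyl in place of hydrogen on an amide-type nitrogen. That change brought a number 83 percentage points lower from compound 3 to compound 1 (beyond the scatter), so the unsubstituted amide sits at the top of the three measured numbers while the cyclopropyl amide is far below it. Compound 2 carries a different core; the difference between the two cores is not broken down here. In this assay compound 2 is level with compound 3 at the digits reported, and the two stand together at the highest of the three numbers.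

Compound 4, `O=C(/C=C1\CCc2cc(F)c(F)cc21)NC1CC1`, is not yet measured. It differs from compound 2 by cyclopropyl in place of hydrogen on an amide-type nitrogen, the same kind of change as that from compound 3 to compound 1, made here on the core of compound 2 rather than the core of compound 3. Going by the values given here, only one such step has been measured, and it was large. Compound 2 starts from the same level as compound 3, so the room for a fall is the same. Compound 4 is therefore expected to give 30% in this assay, with a plausible range from 5% to 70%. This means an expected step of a number 70 percentage points lower from compound 2 to compound 4 (beyond the scatter). That expectation for compound 4 rests on the measured drop, a number 83 percentage points lower from compound 3 to compound 1 (beyond the scatter).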

Compound 4, a percentage reported as inhibition, in the whole organism at one dose (the size of the read-out at that dose, not a potency): 50%
Beside the measured number, compound 4's estimate is 20 percentage points below it, within the range that was stated.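

On the core of compound 2, cyclopropyl in place of hydrogen on an amide-type nitrogen again lowers the number in this assay, with a number 50 percentage points lower from compound 2 to compound 4 (beyond the scatter), so on both cores shown the change moves the read-out in the same direction and by a large amount. The size of the fall, however, does not carry over unchanged from one core to the other, even though both unsubstituted amides, compound 2 and compound 3, stand level at the digits printed: the same change on two cores in this assay, a number 83 percentage points lower (beyond the scatter) from compound 3 to compound 1 and a number 50 percentage points lower (beyond the scatter) from compound 2 to compound 4, 33 percentage points apart, beyond the scatter of two such steps This shows that the core has a say in how much is lost, but it does not show which part of the core is responsible, why the falls differ, or how the change would behave on a third core, and two pairs tested at a single dose are too few to set a rule.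

The compounds shown leave open whether methyl or a longer chain such as n-butyl on the same amide-type nitrogen would bring a fall of similar size on each core, or whether the result is tied to cyclopropyl itself. They also leave open how a carboxylic acid in place of the amide would read on either core.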